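Trifluoromethoxy for fluoro on the outer phenyl

The compounds below may be only part of what the source reports. "The series", "measured", "known", "first", "only" and "open" are said of these compounds alone.

Compound 2 `COc1cc2[nH]c(C)c(-c3ccc(Oc4ccc(F)cc4)cc3)c(=O)c2cc1Cl` carries a fluoro group on the outer phenyl ring. In an ADME assay on HepG2 cells (Homo sapiens) for cytotoxicity, read by resazurin assay, with a stated time of 24 h (a lower number here means a stronger inhibitor, a higher number a weaker inhibitor), compound 2 gives only a limit of the assay, > 10000 nM, and no number. For the measured compounds named here, compound 1 `Cc1[nH]c2ccc(Cl)cc2c(=O)c1-c1ccc(Oc2ccc(OC(F)(F)F)cc2)cc1` differs from compound 2 in more than one place, so no single step between them is counted. In this assay compound 1 likewise reaches only a limit, > 10000 nM. Both values therefore sit at the same edge of the measurement, as noted in the limit of > 10000 nM in this assay, at which 2 of the 2 values shown sit, and compound 2 stands nowhere above or below compound 1 on the numbers shown.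

Compound 3 `COc1cc2[nH]c(C)c(-c3ccc(Oc4ccc(OC(F)(F)F)cc4)cc3)c(=O)c2cc1Cl` has not yet been measured in this assay. Compound 3 differs from compound 2 as follows: trifluoromethoxy in place of fluoro on an aromatic carbon. Going by the values given here, the two measured compounds carry different groups at this place and both stay at the limit, so no measured step gives a direction for this change. The expectation is that compound 3 also remains at or beyond the limit, a step from compound 2 of a step that the limit leaves unreadable from compound 2 to compound 3 that is not expected to exceed the scatter. Compound 3 is thus estimated at 15000 nM, within 7000 nM to 40000 nM.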

Compound 3, half-maximal inhibitory concentration: > 10000 nM
Compound 3 was reported as a limit (the forecaster's own chance of this, stated with the estimate: 85%); the middle value lies beyond the limit too.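

For the compounds shown here, compound 3 joins compound 1 and compound 2 at the limit of this assay, so neither the step to compound 3 from compound 2 nor the one from compound 1 can be read: the limit of > 10000 nM in this assay, at which 3 of the 3 values shown sit. The compounds shown leave open whether any change on the outer phenyl or the shared core would give a readable number in this assay.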